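The source may hold more compounds than are shown below. What is called first, only, known or untested is meant among the compounds shown, and "the series" means these compounds.

Of the compounds shown here, three sharing one core have been measured in a functional assay on A549 cells (Homo sapiens) for antiproliferative activity, read by MTT assay, with a stated time of 72 h; a higher number here means a weaker inhibitor, a lower number a stronger inhibitor. Compound 1 `O=C(CCCCCCc1nc(-c2ccccc2)no1)C(F)(F)F` gives 7680 nM, and compound 3 `O=C(CCCCCCc1nc(-c2ccc(C(F)(F)F)cc2)no1)C(F)(F)F` gives 28800 nM. Compound 2 `Cc1ccc(-c2noc(CCCCCCC(=O)C(F)(F)F)n2)cc1` reads > 100000 nM, which is a limit of the assay and not a number. For the measured compounds named here, of the two exact numbers, the one for compound 3 is the higher, and the gap to its nearest neighbour is a 3.8-fold higher number from compound 1 to compound 3 (0.57 log units; beyond the scatter).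

Compound 4 `O=C(CCCCCCc1nc(-c2ccc(F)cc2)no1)C(F)(F)F`, not yet measured, differs from compound 3 by fluoro in place of trifluoromethyl on an aromatic carbon, para to a large group. Going by the values given here, no measured step brings in fluoro, so the evidence is indirect. Replacing hydrogen on an aromatic carbon gave a modest rise with trifluoromethyl, a 3.8-fold higher number from compound 1 to compound 3 (0.57 log units; beyond the scatter), and a large one with methyl, an at least 13-fold higher number from compound 1 to compound 2 (1.11 log units; beyond the scatter). The exchange of these two groups also moved the number, an at least 3.4-fold lower number from compound 2 to compound 3 (0.54 log units; beyond the scatter). Both replacements of hydrogen raised the number, so removing trifluoromethyl is expected to reverse part of the first step, provided fluoro behaves more like hydrogen. A modest fall is therefore expected in this assay. The estimated change is a 2.4-fold lower number from compound 3 to compound 4 (0.38 log units; beyond the scatter). For compound 4 the expected value is 12000 nM, with an estimated range from 4000 nM to 40000 nM.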

Compound 4, half-maximal inhibitory concentration: > 100000 nM
Compound 4: a limit, no number; the forecaster's own chance of this, stated with the estimate: 5%; at least 8.3-fold (0.92 log units) between middle value and limit.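

In this assay fluoro on the aromatic carbon, para to a large group, does not behave like hydrogen: the change from the unsubstituted ring gives an at least 13-fold higher number from compound 1 to compound 4 (1.11 log units; beyond the scatter) and the exchange with trifluoromethyl gives an at least 3.4-fold higher number from compound 3 to compound 4 (0.54 log units; beyond the scatter), both of them minimum sizes set by a limit of the assay. Among the compounds shown, therefore, methyl, trifluoromethyl and fluoro all give a higher number than hydrogen at this place, with no compound going against that, and the count of heavy atoms does not order the results, since fluoro with 1 heavy atom reads higher than trifluoromethyl with 4. The step from compound 2 to compound 4 cannot be read, because both stand at a limit of the assay: the limit of > 100000 nM in this assay, at which 2 of the 4 values shown sit.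

As far as these compounds go, how far the true values of compound 2 and compound 4 lie beyond that limit stays open, so methyl and fluoro cannot be placed in order. Also open, from the compounds shown here alone, is whether a chlorine, a methoxy group or an amine at this place, or fluoro at another place on the ring, would give a number lower than that of compound 1.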